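The source may hold more compounds than are shown below. What is called first, only, known or untested is meant among the compounds shown, and "the series" means these compounds.

Working notes on the series. Compound 1 `COc1cc(O)c(C(=O)/C=C/c2ccc(F)cc2)c(OC)c1`, compound 2 `COc1cc(OC)c(C(=O)/C=C/c2ccc(Cl)cc2)c(OC)c1` and compound 3 `COc1cccc(/C=C/C(=O)c2c(O)cc(OC)cc2OC)c1` have been run in a functional assay on NCI-H727 cells (Homo sapiens) for cytotoxicity, with a stated time of 48 h; on this read-out lower numbers stand for stronger inhibition and higher numbers for weaker inhibition. Compound 1 returns only a limit of the assay, > 20000 nM, and (the limit of > 20000 nM in this assay, at which 1 of the 3 values shown sits). Compound 2 gives 6000 nM, the lowest of the two numbers in hand. Compound 3 gives 14800 nM, a higher number, and the gap from compound 2 lies beyond the usual scatter. Within the data shown here, compound 3 also differs from compound 2 in its core, so only the two values themselves can be set side by side; no pair of measured compounds here differs in a single place.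

Compound 4 `COc1cc(OC)c(C(=O)/C=C/c2ccccc2OC)c(OC)c1` has not yet been measured in this assay. It keeps the core of compound 2 and changes the ring attached to the chain: 2-methoxyphenyl in place of 4-chlorophenyl on a double-bonded chain carbon bound to a double-bonded chain carbon. Among the measured compounds shown here, with no measured single-place step in the set, this change has no direct precedent. In this assay the expected step of a 1.7-fold higher number from compound 2 to compound 4 (0.22 log units; within the scatter) is a modest weakening, an upward move in the number, though a result within the scatter of compound 2 would not surprise. Compound 4 is accordingly estimated at 10000 nM, with a range from 3000 nM to 30000 nM.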

Compound 4, half-maximal inhibitory concentration: 4000 nM
For compound 4 the middle estimate is 2.5-fold (0.40 log units) above the measured one; the measured number falls inside the stated range.
By their numbers in this assay, from the lowest: compounds 4 and 2 (each within the scatter of the next); then compound 3. At a limit, above all of these: compound 1.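

In this assay the series now has its first single-place step: 2-methoxyphenyl in place of 4-chlorophenyl on a double-bonded chain carbon bound to a double-bonded chain carbon gives a 1.5-fold lower number from compound 2 to compound 4 (0.18 log units; within the scatter) and so leaves the two compounds indistinguishable on this read-out. This position on the shared core therefore accepts two different substituted phenyl groups with no separation beyond the scatter, even though the entering group carries a hydrogen-bond acceptor that the leaving group lacks. No measurement shown bears on why these two groups read alike.

Open, on these data alone, is whether this tolerance extends beyond the two phenyl groups in hand, for instance whether a phenyl group carrying an amine or a carboxylic acid at this position would stay within the scatter of compound 2 or move clearly away from it. Also open, as far as these compounds go, is whether the same exchange of 4-chlorophenyl for 2-methoxyphenyl would read alike on the core of compound 3, where a single-place comparison is still lacking.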